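Butyl to 3-chloropropyl: compound 3 awaits its number

The source may report more compounds than this note shows. Statements on the series, on what has been measured and on what is new or still open speak of the compounds shown alone.

In a functional assay on IMR-32 cells (Homo sapiens) for antiproliferative activity, read by sulforhodamine B assay, with a stated time of 48 h (a lower number here means a stronger inhibitor of growth, a higher number a weaker inhibitor of growth), compound 1 `O=C1COc2ccccc2N1CCCn1cc(-c2cccnc2)nn1` gives 860 nM, while compound 2 `CCCCc1cn(CCCN2C(=O)COc3ccccc32)nn1` gives 5700 nM, the higher of the two numbers. Compound 3 `O=C1COc2ccccc2N1CCCn1cc(CCCCl)nn1` differs from compound 2 in one place: chloro in place of methyl on a saturated chain carbon, three bonds along the chain from an aromatic carbon. Cut one bond further out, the same difference reads butyl to 3-chloropropyl. Within the data shown here, only one measured step bears on this change, and only loosely: a 6.6-fold higher number from compound 1 to compound 2 (0.82 log units; beyond the scatter), with butyl in place of pyridin-3-yl on an aromatic carbon. Among the measured compounds shown here, that step replaced the whole group, whereas compound 3 retains the chain length of compound 2, and no measured pair shows chloro in place of methyl. A much smaller change in this assay is therefore expected, with no shift beyond the scatter and no firm direction. The expected step is a 1.3-fold lower number from compound 2 to compound 3 (0.10 log units; within the scatter). The estimated value for compound 3 is 4500 nM, within an expected range of 1800 nM to 11000 nM.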

Compound 3, concentration for 50% growth inhibition: 200 nM
Beside the measured number, compound 3's estimate is 23-fold (1.35 log units) above it; the measured number lies below the stated range.
By their numbers in this assay, from the lowest: compound 3; then compound 1; then compound 2.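

In this assay, the saturated chain carbon three bonds along the chain from an aromatic carbon proves highly sensitive to what it carries: chloro in place of methyl, with the chain length unchanged, gives a 29-fold lower number from compound 2 to compound 3 (1.45 log units; beyond the scatter). The earlier pair had favoured pyridin-3-yl over butyl, but 3-chloropropyl reverses that order, with a 4.3-fold lower number from compound 1 to compound 3 (0.63 log units; beyond the scatter), so a saturated chain on this aromatic carbon can give a lower number than pyridin-3-yl. No measurement at hand accounts for the effect of the chloro group.

On these data alone, whether this step is specific to chloro remains open, since fluoro, bromo, hydroxyl or an amine at the same carbon could each be compared with it. It is also unclear how the step depends on chain length, which 2-chloroethyl or 4-chlorobutyl would test.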